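The source may hold more compounds than are shown below. What is called first, only, known or untested is meant among the compounds shown, and "the series" means these compounds.

In a functional assay on the whole organism with Homo sapiens as the target, read by calcium flux (on this read-out higher numbers stand for weaker inhibition and lower numbers for stronger inhibition), compound 1 (`COc1ccc(CCCCCCCCOc2ccc(CSc3cccc(C(=O)O)c3)nc2/C=C/C(=O)O)cc1`) gives 550 nM, compound 2 (`COc1ccc(CCCCCCCCOc2ccc(CSCc3ccccc3C(=O)O)nc2/C=C/C(=O)O)cc1`) gives 710 nM and compound 3 (`O=C(O)/C=C/c1nc(CSCc2cccc(C(=O)O)c2)ccc1OCCCCCCCCc1ccccc1`) gives 320 nM. Compound 3 thus stands within the scatter of compound 1, and its number is lower than that of compound 2 by more than the scatter. The next compound to be read is compound 4 (`O=C(O)/C=C/c1nc(CSCc2cccc(C(=O)O)c2)ccc1OCCCCc1ccccc1`). The change is phenyl in place of 4-phenylbutyl on a saturated chain carbon, four bonds along the chain from an oxygen on an aromatic ring. Going by the values given here, only one measured step bears on the series, a 1.3-fold higher number from compound 1 to compound 2 (0.11 log units; within the scatter), and it lies at the group on sulfur, not in this chain. Among the compounds with values here, no measured compound shows what shortening the chain does in this assay, so the forecast is a cautious judgement with a wide range. A move to a higher number, beyond the scatter, is expected, and the expected step is a 4.7-fold higher number from compound 3 to compound 4 (0.67 log units; beyond the scatter). Compound 4 is estimated at 1500 nM, with an expected range from 450 nM to 5000 nM.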

Compound 4, half-maximal inhibitory concentration: 500 nM
The estimate for compound 4 lay 3.0-fold (0.48 log units) above the measured number; the range from low to high includes it.
By their numbers in this assay, from the lowest: compounds 3, 4, 1 and 2 (each within the scatter of the next, the first and the last beyond it).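

In this assay, going by these compounds alone, the step to phenyl in place of 4-phenylbutyl, on a saturated chain carbon, four bonds along the chain from an oxygen on an aromatic ring, gives a 1.6-fold higher number from compound 3 to compound 4 (0.19 log units; within the scatter), the first reading at this position. The group leaving has 10 heavy atoms and the one entering has 6, and both carry a six-membered aromatic ring of carbon only, yet this pair cannot be told apart, so for compound 3 and compound 4 the cut in the chain leaves the number within the scatter. Nothing measured accounts for this result. Going by these compounds, whether that holds for a longer chain, or for an amine in place of the phenyl, remains open. On these data alone, it is also open whether the same cut reads alike with the other groups on sulfur, since this step rests on a single pair.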